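Moving the methyl around the phenylurea ring

This account rests on a few compounds, and the source may have more. Where it says the series, first, only, none or still open, it means among the compounds named here.

Compound 1 `CC1(C)CC(NC(=O)Nc2ccccc2)c2cc(Br)ccc2O1` carries an unsubstituted phenyl on the urea; in a functional assay (aorta) with Rattus norvegicus as the target (a lower number here means that less compound is needed, a higher number that more compound is needed for the effect), compound 1 gives 2300 nM. Compound 2 `COc1ccccc1NC(=O)NC1CC(C)(C)Oc2ccc(Br)cc21` adds a methoxy group to that phenyl, and in this assay compound 2 reaches only the limit > 10000 nM. Compound 3 `Cc1cccc(NC(=O)NC2CC(C)(C)Oc3ccc(Br)cc32)c1` adds a methyl group instead, and in this assay compound 3 likewise reaches only the limit > 10000 nM. The two steps from the unsubstituted parent, an at least 4.3-fold higher number from compound 1 to compound 2 (0.63 log units; beyond the scatter) and an at least 4.3-fold higher number from compound 1 to compound 3 (0.63 log units; beyond the scatter), are both beyond the scatter, while the comparison of the two substituted compounds is a step that the two limits leave unreadable from compound 2 to compound 3. Compound 3 therefore stands at the limit (the limit of > 10000 nM in this assay, at which 2 of the 3 values shown sit), at the weak end of the numbers shown.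

Compound 4 `Cc1ccc(NC(=O)NC2CC(C)(C)Oc3ccc(Br)cc32)cc1` differs from compound 3 by 4-methylphenyl in place of 3-methylphenyl on an amide-type nitrogen. Within the data shown here, no measured step moves a group from one position to another; the only steps that bear on this change are those adding a substituent to the phenyl, and both carried compound 1 beyond the limit. With compound 3 itself at a limit, the direction of the step cannot be read, and the expectation is that compound 4 also sits near the limit, with a step of an at least 1.2-fold lower number from compound 3 to compound 4 (0.09 log units; that floor lies within the scatter). The estimated value of compound 4 in this assay is 8000 nM, within a range from 2500 nM to 30000 nM.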

Compound 4, half-maximal effective concentration: > 30000 nM
Compound 4: no number, only a limit; the forecaster's own chance of this, stated with the estimate: 55%; middle value at least 3.7-fold (0.57 log units) from the limit.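

In this assay the change to 4-methylphenyl gives an at least 13-fold higher number from compound 1 to compound 4 (1.11 log units; beyond the scatter), the largest step readable so far. All three substituted compounds now stand beyond the scatter from the unsubstituted compound 1, and none of the compounds shown goes against this, so the 4-methylphenyl form offers no way back toward the parent. Compound 4 gives only a limit, not a number, and that limit lies higher than the one reached by the other substituted compounds: the limit of > 30000 nM in this assay, at which 1 of the 4 values shown sits.

The steps from compound 3 to compound 4 and from compound 2 to compound 4 cannot be read, with limits at both ends, so moving the methyl from 3-methylphenyl to 4-methylphenyl has no readable size. The compounds shown leave open how far past their limits compound 2, compound 3 and compound 4 really lie, and so whether they differ from one another at all. They also leave open whether a fluorine, a chlorine or a carboxylic acid in place of the methyl of compound 4 would stay as far from compound 1 as the methyl does.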